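Lengthening the hydroxycarbamoyl chain of compound 3

The source may report more compounds than this note shows. Statements on the series, on what has been measured and on what is new or still open speak of the compounds shown alone.

In a functional assay on MCF7 cells (Homo sapiens) for antiproliferative activity, read by CCK-8 assay, with a stated time of 72 h (a lower number here means a stronger inhibitor, a higher number a weaker inhibitor), compound 1 (`CCOc1cc(C(C)(C)C)ccc1C1=NC(c2ccc(Cl)cc2)C(c2ccc(Cl)cc2)N1C(=O)NCCCCCCCC(=O)Nc1ccccc1N`) gives 20300 nM and compound 2 (`CCOc1cc(C(C)(C)C)ccc1C1=NC(c2ccc(Cl)cc2)C(c2ccc(Cl)cc2)N1C(=O)NCCCCCCCC(=O)NO`) gives 7920 nM while compound 3 (`CCOc1cc(C(C)(C)C)ccc1C1=NC(c2ccc(Cl)cc2)C(c2ccc(Cl)cc2)N1C(=O)N1CCN(CCCCC(=O)NO)CC1`) gives 9800 nM on the same read-out. Compound 3 thus stands level with compound 2, within the scatter, and its number lies beyond the scatter under that of compound 1. Compound 4 (`CCOc1cc(C(C)(C)C)ccc1C1=NC(c2ccc(Cl)cc2)C(c2ccc(Cl)cc2)N1C(=O)N1CCN(CCCCCCCC(=O)NO)CC1`) keeps everything in compound 3 except the end of the chain. The change (3-(hydroxycarbamoyl)propyl in place of hydroxycarbamoyl on a saturated chain carbon, four bonds along the chain from an amine nitrogen in a ring) amounts to 3-(hydroxycarbamoyl)propyl in place of hydroxycarbamoyl on a saturated chain carbon, four bonds along the chain from an amine nitrogen in a ring. For the measured compounds named here, the only measured step (a 2.6-fold lower number from compound 1 to compound 2 (0.41 log units; beyond the scatter)) puts hydroxy in place of 2-aminophenyl on an amide-type nitrogen. It is modest and leaves the chain untouched, so it bears only indirectly. Going by the values given here, compound 2 at 7920 nM and compound 3 at 9800 nM lie within the scatter of each other despite their different chains, and no measured pair changes chain length alone. No step beyond the scatter is therefore expected in this assay, and no firm direction can be given. The estimated change is small (a 1.2-fold lower number from compound 3 to compound 4 (0.09 log units; within the scatter)) and is expected to stay within the scatter. For compound 4 the expected value is 8000 nM with an estimated range from 3500 nM to 17000 nM in most repeat measurements.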

Compound 4, half-maximal inhibitory concentration: 4830 nM
Estimate against measurement, compound 4: 1.7-fold (0.22 log units) above; measured number inside the range.
By their numbers in this assay, from the lowest: compounds 4, 2 and 3 (each within the scatter of the next, the first and the last beyond it); then compound 1.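

In this assay, putting 3-(hydroxycarbamoyl)propyl in place of hydroxycarbamoyl on a saturated chain carbon, four bonds along the chain from an amine nitrogen in a ring, gives a 2.0-fold lower number from compound 3 to compound 4 (0.31 log units; beyond the scatter). For the compounds shown here, this is the only measured pair in which the chain length alone changes, and it shows that the read-out responds to this change at this position, towards a lower number, although the step is modest and lies only just beyond the scatter. Nothing available here accounts for the step.

With only two chain lengths compared at this position, the compounds shown leave open whether an intermediate chain would fall between compound 3 and compound 4 and whether a still longer chain would lower the number further or raise it again. They also leave open whether the same lengthening would give a similar step with a carboxylic acid or a primary amide at the chain end in place of the hydroxycarbamoyl group.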